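Replacing the Sulfonyl Ring: Thiomorpholine to Pyrrolidine

A few compounds are considered here, and "the series" means these few. Any claim that something is new, unique, unknown or untested is made for them only; others in the source may bear on it.

The series shares the core of compound 1 `CC(O)(C(=O)Nc1ccc(Sc2ccccc2)cc1)C(F)(F)F`, an amide bearing a trifluoromethyl group and a hydroxyl, and the compounds differ in what sits on the aromatic ring. In an assay on a protein complex (Cavia porcellus) with sulfonylurea receptors; K-ATP channels (Homo sapiens) as the target (a lower number here means a stronger inhibitor, a higher number a weaker inhibitor), compound 1 reaches only the limit of the assay, > 30000 nM, and gives no number. Compound 2 `CC(O)(C(=O)Nc1ccc(S(=O)(=O)N2CCOCC2)cc1)C(F)(F)F` carries a morpholin-4-yl on a sulfonyl sulfur and gives 5850 nM in this assay. Compound 3 `CC(O)(C(=O)Nc1ccc(S(=O)(=O)N2CCSCC2)cc1)C(F)(F)F` has thiomorpholin-4-yl in that place and gives 4580 nM. The step of a 1.3-fold lower number from compound 2 to compound 3 (0.11 log units; within the scatter) shows that exchanging one six-membered ring for another on the sulfonyl sulfur hardly moved the number, so compound 3 stands beside compound 2 with no real separation between them.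

Compound 4 `CC(O)(C(=O)Nc1ccc(S(=O)(=O)N2CCCC2)cc1)C(F)(F)F` takes the exchange one step further: pyrrolidin-1-yl in place of thiomorpholin-4-yl on a sulfonyl sulfur. Within the data shown here, the only measured step that bears on it, a 1.3-fold lower number from compound 2 to compound 3 (0.11 log units; within the scatter), was within the scatter, so no shift beyond the scatter in this assay is expected from compound 3 to compound 4. Compound 4 is therefore estimated at 5000 nM, between 1500 nM and 16000 nM, a step of a 1.1-fold higher number from compound 3 to compound 4 (0.04 log units; within the scatter).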

Compound 4, half-maximal inhibitory concentration: 880 nM
Beside the measured number, compound 4's estimate is 5.7-fold (0.75 log units) above it; the whole stated range lies above it.
By their numbers in this assay, from the lowest: compound 4; then compounds 3 and 2 (each within the scatter of the next). At a limit, above all of these: compound 1.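

In this assay, the place on a sulfonyl sulfur now proves responsive: where the exchange between six-membered rings stayed within the scatter, the five-membered pyrrolidin-1-yl gives a 5.2-fold lower number from compound 3 to compound 4 (0.72 log units; beyond the scatter) and a 6.6-fold lower number from compound 2 to compound 4 (0.82 log units; beyond the scatter), both beyond the scatter. Set against the phenylsulfanyl group on an aromatic carbon, (pyrrolidin-1-yl)sulfonyl gives an at least 34-fold lower number from compound 1 to compound 4 (1.53 log units; beyond the scatter). That step is a bound and not a measured gap, as compound 1 stands at a limit: the limit of > 30000 nM in this assay, at which 1 of the 4 values shown sits.

Compound 4 differs from compound 2 and compound 3 both in ring size and in lacking the second ring hetero atom, so the compounds shown cannot separate these two changes. From the compounds shown here alone, how piperidin-1-yl, a six-membered ring with only the nitrogen, or azetidin-1-yl, a smaller ring still, would stand at this place remains open.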